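Swapping the chain on the amide-type nitrogen

The source may report more compounds than this note shows. Statements on the series, on what has been measured and on what is new or still open speak of the compounds shown alone.

Three compounds have numbers in a physicochemical assay for solubility, in phosphate buffer, at pH 6.5 (a higher number here means a more soluble compound, a lower number a less soluble compound), so far. Compound 1 `C=C[C@@H]1C[C@]1(NC(=O)[C@@H]1C[C@@H](Oc2nccc3cc(OC)ccc23)CN1C(=O)[C@@H](NC(=O)N[C@H](COC)C(C)C)C(C)(C)C)C(=O)NS(=O)(=O)C1CC1` stands at 570 ug/mL and compound 2 `C=C[C@@H]1C[C@]1(NC(=O)[C@@H]1C[C@@H](Oc2nccc3cc(OC)ccc23)CN1C(=O)[C@@H](NC(=O)N[C@H](COC)C(C)(C)C)C(C)(C)C)C(=O)NS(=O)(=O)C1CC1` stands at 609 ug/mL with a 1.1-fold higher number from compound 1 to compound 2 (0.03 log units; within the scatter) as the step that joins them. Compound 3 `C=C[C@@H]1C[C@]1(NC(=O)[C@@H]1C[C@@H](Oc2nccc3cc(OC)ccc23)CN1C(=O)[C@@H](NC(=O)N[C@H](COC)CC(C)C)C(C)(C)C)C(=O)NS(=O)(=O)C1CC1` is the lowest of the set at 225 ug/mL and is reached by a 2.5-fold lower number from compound 1 to compound 3 (0.40 log units; beyond the scatter) and by a 2.7-fold lower number from compound 2 to compound 3 (0.43 log units; beyond the scatter) as two modest steps.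

Compound 4 `C=C[C@@H]1C[C@]1(NC(=O)[C@@H]1C[C@@H](Oc2nccc3cc(OC)ccc23)CN1C(=O)[C@@H](NC(=O)N[C@H](C(=O)O)C(C)(C)C)C(C)(C)C)C(=O)NS(=O)(=O)C1CC1` is not yet measured. It puts 1-carboxy-2,2-dimethylpropyl in place of 1-(methoxymethyl)-3-methylbutyl on an amide-type nitrogen, and the change counts as 1-carboxy-2,2-dimethylpropyl in place of 1-(methoxymethyl)-3-methylbutyl on an amide-type nitrogen in full.

For the measured compounds named here, no measured step brings in a carboxy group, and that limits what the three numbers can say. The closest guide is the chain change at this same place, where a 2.7-fold lower number from compound 2 to compound 3 (0.43 log units; beyond the scatter) shows the only size on record for a swap from a tert-butyl chain. Compound 4 also carries a tert-butyl end, and compound 3 already sits at the bottom of the set. A rise beyond the scatter is therefore expected, larger than the measured steps and with wide uncertainty. The expected step is a 3.6-fold higher number from compound 3 to compound 4 (0.55 log units; beyond the scatter) on this estimate. Compound 4 is expected at 800 ug/mL (estimated range 280 ug/mL to 2500 ug/mL).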

Compound 4, solubility: > 1160 ug/mL
Compound 4: only a limit was reported; the forecaster's own chance of this, stated with the estimate: 10%; middle value at least 1.4-fold (0.16 log units) from the limit.
By their numbers in this assay, from the lowest: compound 3; then compounds 1 and 2 (each within the scatter of the next). At a limit, above all of these: compound 4.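

In this assay, compound 4, with 1-carboxy-2,2-dimethylpropyl on the amide-type nitrogen, brings the first carboxy group to this position and is reported only as a limit, not a number: the limit of > 1160 ug/mL in this assay, at which 1 of the 4 values shown sits.

Even as a floor, the step of an at least 5.1-fold higher number from compound 3 to compound 4 (0.71 log units; beyond the scatter) is larger than any step among the chain swaps at this position, so this change reaches further than swapping one alkyl end for another. The cleanest comparison is carboxy in place of methoxymethyl with the tert-butyl end kept, an at least 1.9-fold higher number from compound 2 to compound 4 (0.27 log units; that floor lies within the scatter), and the companion step is an at least 2.0-fold higher number from compound 1 to compound 4 (0.30 log units; that floor lies within the scatter); both floors lie within the scatter, so the gain over these two chains is not established beyond it.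

For the compounds shown here, the real size of the carboxy effect stays open while the only reading is a limit, and the series gives no separate view of how much comes from the carboxy group and how much from the shorter chain in the step from the isobutyl-ended compound. As far as these compounds go, whether a methyl ester, a primary carboxamide or an amine on the same tert-butyl chain would give a similar reading is also open.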